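Oxolanylmethyl in place of the bicyclic group on compound 3

The source may report more compounds than this note shows. Statements on the series, on what has been measured and on what is new or still open speak of the compounds shown alone.

Compound 3 `COc1ncccc1C(=O)NCCC1CCN(S(=O)(=O)NC(=O)NC[C@@H]2C[C@@H]3CC[C@@H]2C3)CC1` gives the highest of the three numbers in a functional assay on the whole organism (blood) with Rattus norvegicus as the target, with stated times of 24 h and 1 h, at a dose of 5 mg/kg by the intraperitoneal route (on this read-out higher numbers stand for a stronger effect at the one dose given and lower numbers for a weaker effect), with 35%. Compound 1 `COc1ncccc1C(=O)NCCC1CCN(S(=O)(=O)NC(=O)NC2CCCCC2)CC1` gives 33% in this assay, and compound 2 `COc1ncccc1C(=O)NCCC1CCN(S(=O)(=O)NC(=O)NC[C@H]2C[C@@H]3C=C[C@@H]2C3)CC1` gives 20%. Compound 4 `COc1ncccc1C(=O)NCCC1CCN(S(=O)(=O)NC(=O)NCC2CCCO2)CC1` has not yet been measured; it differs from compound 3 by a group of 5 heavy atoms (4 carbon, 1 oxygen; one five-membered non-aromatic ring with 1 hetero atom) in place of a group of 7 heavy atoms (7 carbon; 2 five-membered non-aromatic rings of carbon only), on a saturated chain carbon bound to an amide-type nitrogen. The step that bears most on this change is the one at the same place, a number 15 percentage points higher from compound 2 to compound 3 (beyond the scatter), which shows that swapping groups on that saturated chain carbon can move the read-out modestly. The steps of a number 13 percentage points lower from compound 1 to compound 2 (beyond the scatter) and a number 2 percentage points higher from compound 1 to compound 3 (within the scatter) show the same span across the three compounds. A modest fall is therefore expected, a number 10 percentage points lower from compound 3 to compound 4 (within the scatter), and compound 4 is estimated at 25%, between 10% and 40%.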

Compound 4, a percentage reported as activity, at one dose (the size of the read-out at that dose, not a potency): 16%
Compound 4: the middle estimate sits 9 percentage points above what was measured; low and high end bracket the measured number.
By their numbers in this assay, from the lowest: compounds 4 and 2 (each within the scatter of the next); then compounds 1 and 3 (each within the scatter of the next).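

In this assay, putting oxolan-2-yl on the saturated chain carbon bound to an amide-type nitrogen does not hold the level of the all-carbon bicyclic group: a number 19 percentage points lower from compound 3 to compound 4 (beyond the scatter). The (oxolan-2-yl)methyl group also falls short of cyclohexyl, a number 17 percentage points lower from compound 1 to compound 4 (beyond the scatter), while the result stays level with the other bicyclic group, a number 4 percentage points lower from compound 2 to compound 4 (within the scatter), so two quite different groups here give a similar low read-out. Nothing measured here accounts for this. As far as these compounds go, whether an amine or a carboxylic acid on that chain carbon would raise or lower the read-out remains open.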